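From methyl to benzyl on the thiadiazole side

The source may hold more compounds than are shown below. What is called first, only, known or untested is meant among the compounds shown, and "the series" means these compounds.

Measured in a functional assay on HL-60 cells (Homo sapiens) for inhibition, read by CCK-8 assay, with a stated time of 48 h, tested at 20 uM; a lower number here means less inhibition of growth, a higher number more inhibition of growth at the concentration tested:
- compound 1 `Cc1ccc(S(=O)(=O)Oc2ccccc2/C=C(\C#N)C(=O)Nc2nnc(C)s2)cc1`: 78%
- compound 2 `CC(=O)Nc1ccc(S(=O)(=O)Oc2cccc(/C=C(\C#N)C(=O)Nc3nnc(-c4cccs4)s3)c2)cc1`: 71%
- compound 3 `COc1ccc(S(=O)(=O)Oc2ccccc2/C=C(\C#N)C(=O)Nc2nnc(Cc3cccc4ccccc34)s2)cc1`: 98%

In this assay compound 1 gives 78%. That number lies within the usual scatter of compound 2, while compound 3 stands clearly higher than compound 1 and compound 2.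

The next compound to be tested is compound 4 `Cc1ccc(S(=O)(=O)Oc2ccccc2/C=C(\C#N)C(=O)Nc2nnc(Cc3ccccc3)s2)cc1`. It departs from compound 1 by one change, phenyl in place of hydrogen on a saturated chain carbon bound to an aromatic carbon, which reads as methyl to benzyl.

For the measured compounds named here, no two measured compounds differ in one place only, so the expectation rests on thin evidence. Compound 3, with 98%, also bears an aromatic group on such a chain carbon, but it differs from compound 1 elsewhere too. The estimated step of a number 10 percentage points higher from compound 1 to compound 4 (within the scatter) is upward and near the edge of the scatter. For compound 4 the expected value is 88%, with an estimated range from 74% to 100%.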

Compound 4, percent growth inhibition at one concentration: 16%
Compound 4: the middle estimate sits 72 percentage points above what was measured; the whole stated range lies above it.
By their numbers in this assay, from the lowest: compound 4; then compounds 2 and 1 (each within the scatter of the next); then compound 3.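

In this assay, for the compounds shown here, the change from methyl to benzyl gives a number 62 percentage points lower from compound 1 to compound 4 (beyond the scatter) and is the first change in a single place that can be read in this set. It shows that this saturated chain carbon bound to an aromatic carbon is not a position where substitution is tolerated without consequence, at least on the core of compound 1: one phenyl in place of hydrogen removes most of the growth inhibition at the concentration tested. Nothing measured here explains why the phenyl has this effect.

From the compounds shown here alone, whether an ethyl group, a longer chain or a cyclohexylmethyl group in place of benzyl would retain the activity of compound 1 remains open. Also open, going by these compounds, is whether the same change would have so large an effect on a different core.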